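A few compounds are considered here, and "the series" means these few. Any claim that something is new, unique, unknown or untested is made for them only; others in the source may bear on it.

In an ADME assay on the whole organism (Mus musculus, strain BALB/c) for pharmacokinetics, read by LC-MS, at a dose of 2 mg/kg by the intravenous route (on this read-out higher numbers stand for fast clearance and lower numbers for slow clearance), compound 1 (`COC(=O)NC12CCC(n3cc(-c4ccc(Cl)c(N)c4)c4c(N)ncnc43)(CC1)CC2`) gives 1.4 mL/min/kg and compound 2 (`COC(=O)N[C@H]1CC[C@@H](n2cc(-c3ccc(Cl)c(N)c3)c3c(N)ncnc32)CC1`) gives 1.9 mL/min/kg, so the two stand within the scatter of each other. Compound 3 (`COC(=O)NC12CCC(n3cc(-c4cc(N)c(Cl)cc4F)c4c(N)ncnc43)(CC1)CC2`) keeps the core of compound 1 and differs in one place: fluoro in place of hydrogen on an aromatic carbon, with fluoro in place of hydrogen on an aromatic carbon. Among the measured compounds shown here, no measured pair shows this change, so no shift beyond the scatter is expected in this assay. The expected step is a 1.1-fold higher number from compound 1 to compound 3 (0.06 log units; within the scatter). For compound 3 the estimated clearance is 1.6 mL/min/kg, with an expected range of 0.8 mL/min/kg to 3.5 mL/min/kg.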

Compound 3, clearance: 1.8 mL/min/kg
Estimate against measurement, compound 3: 1.1-fold (0.05 log units) below, and the stated range covers the measured number.
By their numbers in this assay, from the lowest: compounds 1, 3 and 2 (each within the scatter of the next).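

In this assay, fluoro in place of hydrogen on an aromatic carbon, ortho to a large group and para to an amino group, gives a 1.3-fold higher number from compound 1 to compound 3 (0.11 log units; within the scatter). This single pair shows that a fluoro group at this position leaves clearance within the scatter of the parent compound 1, so the low clearance is kept with this change. No measurement at hand bears on the reason for this result.

Still open, going by these compounds, is whether a methoxy or nitrile group at the same position would also stay within the scatter, and whether the same fluoro change would do so on compound 2.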